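This account rests on a few compounds, and the source may have more. Where it says the series, first, only, none or still open, it means among the compounds named here.

Measured compounds:
compound 1, `FC(F)(F)c1ccccc1-c1nc(NCc2ccc(-c3cccc(Cl)c3)cc2)c2ccccc2n1`, 2700 nM in an assay on a protein complex for inhibition of ubiquitin carboxyl-terminal hydrolase 1/WD repeat-containing protein 48 (Homo sapiens), read by fluorescence; a higher number here means a weaker inhibitor, a lower number a stronger inhibitor
compound 2, `FC(F)(F)c1ccc(-c2nc(NCc3ccc(-c4cccnc4)cc3)c3ccccc3n2)cc1`, "not active" (no number reported) in this assay

Compound 2 stands without a single number: in this assay compound 2 is reported as "not active" (no number reported), so no potency value can be placed on it. Going by the values given here, compound 1 and compound 2 differ in more than one place, so nothing is read from the pair as such; the only fact is that compound 1 gives a measured value of 2700 nM while compound 2 gives none.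

Compound 3, `CC(C)c1ccccc1-c1nc(NCc2ccc(-c3cccnc3)cc2)c2ccccc2n1`, has not been measured. It differs from compound 2 by one change: 2-isopropylphenyl in place of 4-(trifluoromethyl)phenyl on an aromatic carbon

Among the compounds with values here, no step between measured compounds exists for this change, so its size and direction cannot be taken from the data. Within the data shown here, compound 2 starts from no number at all, and the only measured neighbour, compound 1, is itself a weak inhibitor at 2700 nM. The expectation is therefore a weak value for compound 3, with a real chance that this assay again reports only a limit. Compound 3 is estimated at 6000 nM in this assay, within a range from 1500 nM to 30000 nM.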

Compound 3, half-maximal inhibitory concentration: 180 nM
For compound 3 the middle estimate is 33-fold (1.52 log units) above the measured one; measured number below the stated range.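

No step can be read from compound 2 to compound 3: in this assay compound 2 gives "not active" (no number reported) while compound 3 gives 180 nM. No evidence shown bears on this result. The compounds shown leave open how much of the potency of compound 3 goes with the 2-isopropylphenyl group itself.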